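Ring amide nitrogen substituent: cyclopropyl to phenyl

The source may hold more compounds than are shown below. What is called first, only, known or untested is meant among the compounds shown, and "the series" means these compounds.

Measured so far:
- compound 1, `COc1ncc(-c2ccc3c(c2)N(c2ccc(F)cc2)C(=O)CO3)cc1NS(=O)(=O)c1ccc(F)cc1`: in a functional assay on A-375 cells (Homo sapiens) for antiproliferative activity, read by MTT assay, with a stated time of 72 h (a lower number here means a stronger inhibitor, a higher number a weaker inhibitor), compound 1 reports only the assay limit, > 40000 nM, not a number.
- compound 2, `COc1ncc(-c2ccc3c(c2)N(C2CC2)C(=O)CO3)cc1NS(=O)(=O)c1ccc(F)cc1`: in this assay compound 2 gives 23900 nM.

For the measured compounds named here, compound 2 holds the only numeric value in this assay within this pair; the other entry is a limit. Going by the values given here, the one measured step is an at least 1.6-fold lower number from compound 1 to compound 2 (0.22 log units; that floor lies within the scatter), and its floor lies within the scatter, so it carries little weight on its own. Its cause cannot be assigned beyond noting (the limit of > 40000 nM in this assay, at which 1 of the 2 values shown sits).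

The unmeasured compound 3, `COc1ncc(-c2ccc3c(c2)N(c2ccccc2)C(=O)CO3)cc1NS(=O)(=O)c1ccc(F)cc1`, differs from compound 2 as phenyl in place of cyclopropyl on an amide-type nitrogen in a ring. This change moves back toward the aryl substituent of compound 1, which differs from phenyl only by a fluorine on the ring. The relevant comparison is therefore the step from compound 1 to compound 2, whose direction suggests that replacing cyclopropyl with an aromatic ring weakens activity, though its size is uncertain because an at least 1.6-fold lower number from compound 1 to compound 2 (0.22 log units; that floor lies within the scatter) is bounded only by the limit.

Compound 3 is expected to give about 40000 nM in this assay, between 18000 nM and 90000 nM. The estimated step is a 1.7-fold higher number from compound 2 to compound 3 (0.22 log units; within the scatter), with a real chance that compound 3 also reports only a limit.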

Compound 3, half-maximal inhibitory concentration: 15200 nM
Beside the measured number, compound 3's estimate is 2.6-fold (0.42 log units) above it; the measured number lies below the stated range.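

On the amide-type nitrogen in a ring, phenyl and cyclopropyl cannot be told apart in this assay: a 1.6-fold lower number from compound 2 to compound 3 (0.20 log units; within the scatter), so an aromatic ring at this position does not by itself carry the compound to the limit. For the compounds shown here, the single fluoro on that ring is the change that separates the two aryl compounds, with an at least 2.6-fold lower number from compound 1 to compound 3 (0.42 log units; beyond the scatter), and this is the only step in the set that clears the scatter; the step from the fluorinated aryl to cyclopropyl, which alone could not be assigned, now reads as a fluoro change rather than an aryl-for-cycloalkyl change. Compound 1 reports a limit, > 40000 nM, not a number, so the size of the fluoro step remains a floor, and its true size cannot be read because of this limit: the limit of > 40000 nM in this assay, at which 1 of the 3 values shown sits.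

As far as these compounds go, whether the fluoro step reflects that atom alone stays open, since a chloro or methoxy group in its place would be needed to separate it from other substituents on the phenyl. From the compounds shown here alone, how far this nitrogen accepts other groups, such as methyl, a longer alkyl chain or a chain ending in an amine, also remains open.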